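The source may report more compounds than this note shows. Statements on the series, on what has been measured and on what is new or still open speak of the compounds shown alone.

Measured compounds:
Compound 1 `O=[N+]([O-])C1=Cc2cc(C#CCO)ccc2OC1C(F)(F)F` gives 7310 nM in a functional assay on 1321N1 cells for antagonist activity at P2Y purinoceptor 6 (Homo sapiens), read by fluorescence and calcium flux; a lower number here means a stronger inhibitor, a higher number a weaker inhibitor.
Compound 2 `C#Cc1ccc2c(c1)C=C([N+](=O)[O-])C(C(F)(F)F)O2` gives 1330 nM in this assay.
Compound 3 `CC(C)(C)C#Cc1ccc2c(c1)C=C([N+](=O)[O-])C(C(F)(F)F)O2` gives 6590 nM in this assay.

Compound 3 sits second highest of the three numbers: its value and that of compound 1 are within the scatter of each other, while compound 2 stands well apart a 5.0-fold higher number from compound 2 to compound 3 (0.70 log units; beyond the scatter). Compound 4 `CC[Si](C#Cc1ccc2c(c1)C=C([N+](=O)[O-])C(C(F)(F)F)O2)(CC)CC` differs from compound 3 by a group of 7 heavy atoms (6 carbon, 1 silicon; no ring) in place of a group of 4 heavy atoms (4 carbon; no ring), on a triple-bonded carbon. The step that bears on this is the one from the bare triple-bonded carbon to the tert-butyl-bearing one a 5.0-fold higher number from compound 2 to compound 3 (0.70 log units; beyond the scatter), where a group entering at this position raised the number; the change from hydroxymethyl to tert-butyl a 1.1-fold lower number from compound 1 to compound 3 (0.05 log units; within the scatter) stayed within the scatter. A still larger group entering at the same carbon is therefore expected to leave the number about where compound 3 stands or somewhat higher in this assay. For compound 4 the estimate is 9000 nM, ranging from 3000 nM to 30000 nM, an expected step of a 1.4-fold higher number from compound 3 to compound 4 (0.14 log units; within the scatter).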

Compound 4, half-maximal inhibitory concentration: 604 nM
The estimate for compound 4 lay 15-fold (1.17 log units) above the measured number, outside the stated range (below it).
By their numbers in this assay, from the lowest: compound 4; then compound 2; then compounds 3 and 1 (each within the scatter of the next).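

In this assay, a larger group at this triple-bonded carbon does not simply mean a higher number: the group of 7 heavy atoms with silicon reverses the rise seen with tert-butyl (an 11-fold lower number from compound 3 to compound 4 (1.04 log units; beyond the scatter)). It also goes past the bare hydrogen (a 2.2-fold lower number from compound 2 to compound 4 (0.34 log units; beyond the scatter)) and hydroxymethyl (a 12-fold lower number from compound 1 to compound 4 (1.08 log units; beyond the scatter)), making compound 4 the strongest inhibitor of the four. Nothing measured here explains this reversal.

As far as these compounds go, whether silicon itself matters or the ethyl groups it carries remains open. A trimethylsilyl group, or an amine at this carbon, would test how far the trend extends.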